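Cytotoxicity limit holds across the amide-nitrogen substituents

A few compounds are considered here, and "the series" means these few. Any claim that something is new, unique, unknown or untested is made for them only; others in the source may bear on it.

Three compounds share one core. Compound 1 `COc1ccc([C@H]2CC(=O)N(Cc3cccc(N)c3)C2)cc1OC1CCCC1`, compound 2 `COc1ccc([C@H]2CC(=O)N(c3ccccc3N)C2)cc1OC1CCCC1` and compound 3 `COc1ccc([C@H]2CC(=O)N(c3cccc(C#N)c3)C2)cc1OC1CCCC1` differ only in the group on the amide-type nitrogen in the ring. In a functional assay on HEK293 cells (Homo sapiens) for cytotoxicity (a lower number here means that less compound is tolerated, a higher number that more compound is tolerated), compound 1 gives > 10000 nM, a limit of the assay and not a number. In this assay compound 2 gives > 10000 nM, again a limit. In this assay compound 3 gives > 10000 nM, also a limit. Because (the limit of > 10000 nM in this assay, at which 3 of the 3 values shown sit), the steps a step that the two limits leave unreadable from compound 1 to compound 2, a step that the two limits leave unreadable from compound 1 to compound 3 and a step that the two limits leave unreadable from compound 2 to compound 3 cannot be read. Compound 2 therefore stands at the limit alongside the two others, with no order among them.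

Compound 4 `COc1ccc([C@H]2CC(=O)N(c3cccc(S(C)(=O)=O)c3)C2)cc1OC1CCCC1` is not yet measured. It differs from compound 2 as follows: 3-(methylsulfonyl)phenyl in place of 2-aminophenyl on an amide-type nitrogen in a ring. The measured steps that bear on it are the three exchanges on the same nitrogen, each unreadable because every value sits at the limit (the limit of > 10000 nM in this assay, at which 3 of the 3 values shown sit). No step beyond the scatter is therefore expected in this assay in either direction, and the expectation is that compound 4 also returns the limit. The implied step that the limit leaves unreadable from compound 2 to compound 4 is expected to stay within the scatter. Compound 4 is expected at 15000 nM, in the range 8000 nM to 40000 nM.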

Compound 4, half-maximal cytotoxic concentration: > 10000 nM
Compound 4: a limit, no number; the forecaster's own chance of this, stated with the estimate: 80%; the middle value is on the limit's open side.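

In this assay compound 4 gives > 10000 nM, a limit and not a number. The steps from compound 1, compound 2 and compound 3 to compound 4 cannot be read, because all four compounds share one limit: the limit of > 10000 nM in this assay, at which 4 of the 4 values shown sit.

The compounds shown leave open how they order among themselves, and whether any group on the amide-type nitrogen gives a measurable cytotoxic concentration.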